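A few compounds are considered here, and "the series" means these few. Any claim that something is new, unique, unknown or untested is made for them only; others in the source may bear on it.

Compound 1 `Nc1nc(-c2ccc(C(F)F)o2)nc2sc(CN3CCC(F)CC3)cc12` in an assay on CHO-K1 cells for antagonist activity at adenosine receptor A1 (Homo sapiens), read by a beta-galactosidase reporter, with stated times of 15 min and 6 h (a lower number here means a stronger inhibitor, a higher number a weaker inhibitor), gives 1670 nM.
Compound 2 `N#Cc1cccc(-c2nc(N)c3cc(CN4CCC(F)CC4)sc3n2)c1` in this assay gives 2950 nM.
Compound 3 `N#Cc1ccccc1-c1nc(N)c2cc(CN3CCC(F)CC3)sc2n1` is not yet measured in this assay.

Among the measured compounds shown here, of the two measured numbers, compound 2 carries the larger figure, but the only step so far, a 1.8-fold higher number from compound 1 to compound 2 (0.25 log units; within the scatter), lies within the scatter, so compound 1 and compound 2 cannot be told apart on this evidence. Compound 3 keeps every atom of compound 2 and differs only in how they are joined: 2-cyanophenyl in place of 3-cyanophenyl on an aromatic carbon. For the measured compounds named here, no measured step moves a nitrile around a ring, so the closest guide is that swapping the whole aryl group in a 1.8-fold higher number from compound 1 to compound 2 (0.25 log units; within the scatter) left the number within the scatter. On that basis, the step of a 1.0-fold higher number from compound 2 to compound 3 (0.01 log units; within the scatter) is expected to stay within the scatter as well, with no clear direction. Compound 3 is therefore estimated at 3000 nM, with a likely range from 900 nM to 10000 nM.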

Compound 3, inhibition constant: 5050 nM
Compound 3: the middle estimate sits 1.7-fold (0.23 log units) below what was measured, within the range that was stated.
By their numbers in this assay, from the lowest: compounds 1, 2 and 3 (each within the scatter of the next, the first and the last beyond it).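

In this assay, moving the nitrile around the ring, with 2-cyanophenyl in place of 3-cyanophenyl, gives a 1.7-fold higher number from compound 2 to compound 3 (0.23 log units; within the scatter) and so does not separate these two arrangements. Among the compounds shown here, replacing 5-(difluoromethyl)furan-2-yl with 2-cyanophenyl on the same aromatic carbon gives a 3.0-fold higher number from compound 1 to compound 3 (0.48 log units; beyond the scatter) and is the first step here to pass the scatter, showing that the group at this position can shift the number, if only modestly. Nothing available explains either step.

As far as these compounds go, it remains open whether a plain phenyl, or a phenyl carrying a methoxy group or a carboxylic acid, would give a lower number than these aryl groups. From the compounds shown here alone, since all three compounds share the rest of their structure, the effect of changing the amino group on the core also remains unknown.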